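The source may report more compounds than this note shows. Statements on the series, on what has been measured and on what is new or still open speak of the compounds shown alone.

In a functional assay on A549 cells (Homo sapiens) for cytotoxicity, read by MTT assay, with a stated time of 72 h (on this read-out lower numbers stand for stronger inhibition and higher numbers for weaker inhibition), compound 3 `Cn1ccc2c(Oc3ccc(NC(=O)c4nn(-c5ccc(Br)cc5)ccc4=O)cc3)ccnc21` gives 59400 nM, the highest of the two numbers obtained. Its nearest neighbour is compound 1 `O=C(Nc1ccc(Oc2ccnc3[nH]ccc23)cc1)c1nn(-c2ccc(Cl)c(F)c2)ccc1=O`, which in this assay gives 2580 nM, a value that lies beyond the scatter below that of compound 3. Compound 2 `COc1ccc(-n2ccc(=O)c(C(=O)Nc3ccc(Oc4ccnc5c4ccn5C)cc3)n2)cc1` in this assay reaches only a limit of the assay, > 60000 nM. Going by the values given here, the single measured step, a number no higher from compound 2 to compound 3 (the limit leaves the size open), leaves its size open, as the limit of > 60000 nM in this assay, at which 1 of the 3 values shown sits, shows. Compound 4 `Cn1ccc2c(Oc3ccc(NC(=O)c4nn(-c5ccc(Cl)c(F)c5)ccc4=O)cc3)ccnc21` carries 4-chloro-3-fluorophenyl in place of 4-bromophenyl on an aromatic nitrogen. Among the compounds with values here, no measured step bears on this exchange: compound 1 holds the same 4-chloro-3-fluorophenyl group yet differs from compound 4 in a second place, and compound 1 and compound 3 differ in two places, so their values show only that the two compounds sit far apart. The size of a 3.0-fold lower number from compound 3 to compound 4 (0.47 log units; beyond the scatter) is therefore an estimate without a direct precedent among the measured pairs. Compound 4 is expected to give 20000 nM in this assay, with a range from 4000 nM to 80000 nM.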

Compound 4, half-maximal inhibitory concentration: > 60000 nM
Compound 4 ended at the assay's limit (the forecaster's own chance of this, stated with the estimate: 25%); at least 3.0-fold (0.47 log units) between middle value and limit.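

Going by these compounds alone, the result supplies the first comparison that differs in one place for methyl in place of hydrogen on an aromatic nitrogen: in this assay, this change gives an at least 23-fold higher number from compound 1 to compound 4 (1.36 log units; beyond the scatter). The wide gap that earlier lay only between compounds differing in two places is thus tied to this single change, with the 4-chloro-3-fluorophenyl group held constant. The value of compound 4 is a limit of the assay. With 4-chloro-3-fluorophenyl in place of 4-bromophenyl on an aromatic nitrogen, the result is a number no lower from compound 3 to compound 4 (the limit leaves the size open). The sizes of this step and of the step from the 4-methoxyphenyl compound cannot be read, because they rest on that limit: the limit of > 60000 nM in this assay, at which 2 of the 4 values shown sit.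

As far as these compounds go, it remains open whether hydrogen in place of methyl would give a similar step with 4-bromophenyl or 4-methoxyphenyl on the other aromatic nitrogen. From the compounds shown here alone, how an ethyl group or a longer chain would read in place of that methyl also stays open.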